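A few compounds are considered here, and "the series" means these few. Any claim that something is new, unique, unknown or untested is made for them only; others in the source may bear on it.

Measured compounds:
compound 1 `Cn1cnnc1-c1cc(Oc2ccc(NC(=O)Nc3cccc(C(F)(F)F)c3)cc2F)ccn1`, a functional assay on NCI-H460 cells (Homo sapiens) for antiproliferative activity, read by MTT assay, with a stated time of 72 h; on this read-out lower numbers stand for stronger inhibition and higher numbers for weaker inhibition: 1270 nM
compound 2 `CCN(CC)CCn1cnnc1-c1cc(Oc2ccc(NC(=O)Nc3cccc(C(F)(F)F)c3)cc2F)ccn1`, this assay: 9870 nM

Among the measured compounds shown here, compound 2 stands at the highest of the two numbers so far; its only neighbour is compound 1, and the single measured step, a 7.8-fold higher number from compound 1 to compound 2 (0.89 log units; beyond the scatter), separates them, which is beyond the scatter.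

Compound 3 `CN(C)CCCn1cnnc1-c1cc(Oc2ccc(NC(=O)Nc3cccc(C(F)(F)F)c3)cc2F)ccn1` differs from compound 2 by (dimethylamino)methyl in place of diethylamino on a saturated chain carbon, two bonds along the chain from an aromatic nitrogen. Cut one bond further out, the same change reads as 2-(diethylamino)ethyl giving way to 3-(dimethylamino)propyl on the triazole nitrogen. The step of a 7.8-fold higher number from compound 1 to compound 2 (0.89 log units; beyond the scatter) bears on this only loosely: there a whole amine-bearing chain entered in place of hydrogen, whereas here one amine-bearing chain replaces another of similar make, each with one hydrogen-bond acceptor and no ring. For the measured compounds named here, no measured pair isolates the chain length or the amine substitution alone. The expectation for this assay is therefore no step beyond the scatter from compound 2, with wide uncertainty. Compound 3 is expected near 7000 nM, within 2500 nM to 20000 nM, which would be the step of a 1.4-fold lower number from compound 2 to compound 3 (0.15 log units; within the scatter) expected from the change.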

Compound 3, half-maximal inhibitory concentration: 1790 nM
For compound 3 the middle estimate is 3.9-fold (0.59 log units) above the measured one, and the stated range ends above it.
By their numbers in this assay, from the lowest: compounds 1 and 3 (each within the scatter of the next); then compound 2.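

In this assay, the cost of the amine-bearing chain at this position is not fixed: swapping 2-(diethylamino)ethyl for 3-(dimethylamino)propyl gives a 5.5-fold lower number from compound 2 to compound 3 (0.74 log units; beyond the scatter), so the result depends on the make-up of the chain and not merely on an amine chain being present. Set against the hydrogen-free methyl-bearing starting point of the series, the chain in compound 3 gives a 1.4-fold higher number from compound 1 to compound 3 (0.15 log units; within the scatter), so this position can carry a chain ending in an amine with no step beyond the scatter, whereas the chain in compound 2 does not. No measurement at hand gives any account of why the two chains differ.

The change alters the chain length and the amine substituents together, so the compounds shown do not say which of the two carries the step; a 3-(diethylamino)propyl or a 2-(dimethylamino)ethyl group at this position would separate them. Also open, from the compounds shown here alone, is whether the tolerance extends to a longer chain or to a chain ending in a cyclic amine such as morpholine, or in a carboxylic acid.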